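A few compounds are considered here, and "the series" means these few. Any claim that something is new, unique, unknown or untested is made for them only; others in the source may bear on it.

Three compounds sharing one core were measured in a toxicity assay (H9c2 cells) for cytotoxicity, with Rattus norvegicus as the target, read by neutral red uptake, with a stated time of 72 h; on this read-out higher numbers stand for weaker inhibition and lower numbers for stronger inhibition. Compound 1 `C/C(=N\NC(=O)c1ccc(-c2ccccc2)cc1)c1ccccc1O` gives only a limit of the assay, > 100000 nM, which is the limit of > 100000 nM in this assay, at which 1 of the 3 values shown sits. Compound 2 `C/C(=N\NC(=O)c1ccnnc1)c1ccccc1O` gives 22800 nM in this assay, and compound 3 `C/C(=N\NC(=O)c1cccnc1)c1ccccc1O` gives 6800 nM in this assay. Of the two numbers shown, compound 3 holds the lower one; the step of a 3.4-fold lower number from compound 2 to compound 3 (0.53 log units; beyond the scatter) lies beyond the scatter, while the value of compound 1 is a limit and not a number. Compound 4 `CC/C(=N\NC(=O)c1cccnc1)c1ccccc1O` has not been measured in this assay. It differs from compound 3 by methyl in place of hydrogen on a saturated chain carbon bound to a carbon with a double bond to nitrogen. Within the data shown here, none of the measured steps touches this place: the single measured step, a 3.4-fold lower number from compound 2 to compound 3 (0.53 log units; beyond the scatter), exchanges the ring on the carbonyl carbon and says nothing about the saturated chain carbon bound to a carbon with a double bond to nitrogen. Among the measured compounds shown here, with no comparable step to draw on, a step of no size beyond the scatter is expected, no change at the digits printed from compound 3 to compound 4 (within the scatter). Compound 4 is therefore estimated at 6800 nM in this assay, within a range from 2500 nM to 20000 nM.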

Compound 4, half-maximal inhibitory concentration: 7100 nM
The estimate for compound 4 lay 1.0-fold (0.02 log units) below the measured number; the measured number falls inside the stated range.
By their numbers in this assay, from the lowest: compounds 3 and 4 (each within the scatter of the next); then compound 2. At a limit, above all of these: compound 1.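

In this assay, among these compounds, the result gives the first reading at this place: a 1.0-fold higher number from compound 3 to compound 4 (0.02 log units; within the scatter). Among the compounds shown here, the change of methyl to ethyl on the carbon bound to the carbon with a double bond to nitrogen therefore leaves the number within the scatter, whereas the only earlier step had exchanged the ring on the carbonyl carbon and gave no information about this place. Nothing shown here bears on the cause of this result.

From the compounds shown here alone, it remains open whether this place would stay as quiet with a longer chain such as propyl, or with an amine or a carboxylic acid on the chain. Going by these compounds, it is also open whether methyl to ethyl reads the same with pyridazin-4-yl on the carbonyl carbon.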